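The source may report more compounds than this note shows. Statements on the series, on what has been measured and on what is new or still open speak of the compounds shown alone.

Three compounds built on a shared core were examined in an assay on isolated protein for inhibition of MAP kinase-activated protein kinase 2 (Homo sapiens), read by mobility shift assay, tested at 30 uM; on this read-out lower numbers stand for less inhibition and higher numbers for more inhibition at the one concentration tested (going by the name of the read-out). Compound 1, `Cc1cc2c(c(N)nn2C)c(N2CCCCC2)n1`, gave 7%. Compound 2, `COCCNc1nc(C)cc2c1c(N)nn2C`, gave 6% in this assay. Compound 3, `COCCNc1nc(C)cc2nn(-c3ccccc3)c(N)c12`, gave 3% in this assay, the lowest of the three numbers, although its gaps to compound 2 and to compound 1 both lie within the usual scatter, so the three numbers cannot be told apart with confidence.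

Compound 1 and compound 2 differ in one place: piperidin-1-yl in place of (2-methoxyethyl)amino on an aromatic carbon. The step that this change made was a number 1 percentage points higher from compound 2 to compound 1 (within the scatter), which lies within the scatter. The difference between the core of compound 2 and the core of compound 3 is not broken down here.

Compound 4, `Cc1cc2nn(-c3ccccc3)c(N)c2c(N2CCCCC2)n1`, has not yet been measured in this assay. It differs from compound 3 by the same change: piperidin-1-yl in place of (2-methoxyethyl)amino on an aromatic carbon. This change occurs twice among the compounds shown, and in its one measured instance it produced a step of a number 1 percentage points higher from compound 2 to compound 1 (within the scatter). Among the measured compounds shown here, the step expected from compound 3 to compound 4 is estimated at a number 1 percentage points higher from compound 3 to compound 4 (within the scatter), a step within the scatter, because the only earlier instance of this change moved the number by a number 1 percentage points higher from compound 2 to compound 1 (within the scatter). Compound 4 is accordingly expected to give about 4% in this assay, with a likely range from -5% to 13%.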

Compound 4, a percentage reported as inhibition, at one concentration (the size of the read-out at that concentration, not a potency): 7%
The estimate for compound 4 lay 3 percentage points below the measured number; the range from low to high includes it.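

Placing piperidin-1-yl where (2-methoxyethyl)amino stood on the core of compound 3 gave a number 4 percentage points higher from compound 3 to compound 4 (within the scatter) in this assay, a step that cannot be told apart from no step at all. Set beside the earlier instance of the same change, the step gives no sign that the two cores respond differently: the same change on two cores in this assay, a number 1 percentage points higher (within the scatter) from compound 2 to compound 1 and a number 4 percentage points higher (within the scatter) from compound 3 to compound 4, 3 percentage points apart, within the scatter of two such steps. Among the compounds shown here, this shows that, on these two cores, the exchange carries over without a step that rises above the scatter, but it does not show that the change would behave alike on other cores, since it rests on only two pairs, and it says nothing about potency, since each number comes from one concentration and all of them lie within the scatter of each other.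

The compounds shown leave open whether any other group on this aromatic carbon, such as a morpholine, a primary amine, a carboxylic acid or a longer chain, would give a number that stands clear of the scatter. They also leave open whether the change would still carry over on a compound with a clearly larger inhibition in this read-out.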